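Naphthyl for Phenyl on the Thiourea Tail

This account rests on a few compounds, and the source may have more. Where it says the series, first, only, none or still open, it means among the compounds named here.

Measured compounds in a functional assay on HL-60 cells (Homo sapiens) for antiproliferative activity, with a stated time of 24 h; a higher number here means a weaker inhibitor, a lower number a stronger inhibitor:
Compound 1 `NC(=O)c1c(NC(=O)c2ccccc2Cl)sc2c1CCNC2` gives 18600 nM.
Compound 2 `NC(=O)c1c(NC(=O)c2ccccc2Cl)sc2c1CCN(Cc1ccc([N+](=O)[O-])cc1)C2` gives 11400 nM.
Compound 3 `NC(=O)c1c(NC(=O)c2ccccc2Cl)sc2c1CCN(C(=S)Nc1ccccc1)C2` gives 5940 nM.

Compound 3 has the lowest number of the three: the step of a 3.1-fold lower number from compound 1 to compound 3 (0.50 log units; beyond the scatter) lies beyond the scatter, whereas the step of a 1.9-fold lower number from compound 2 to compound 3 (0.28 log units; within the scatter) does not, so compound 2 and compound 3 cannot be told apart. Compound 4 `NC(=O)c1c(NC(=O)c2ccccc2Cl)sc2c1CCN(C(=S)Nc1cccc3ccccc13)C2` differs from compound 3 by naphthalen-1-yl in place of phenyl on an amide-type nitrogen. For the measured compounds named here, no measured step touches this part of the molecule; the steps of a 1.6-fold lower number from compound 1 to compound 2 (0.21 log units; within the scatter) and a 3.1-fold lower number from compound 1 to compound 3 (0.50 log units; beyond the scatter) both concern the amine nitrogen in the ring. With nothing to guide the direction, only a change within the usual scatter is expected, a 1.3-fold lower number from compound 3 to compound 4 (0.12 log units; within the scatter). Compound 4 is therefore estimated at 4500 nM, within a range from 1500 nM to 13000 nM.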

Compound 4, half-maximal inhibitory concentration: 13400 nM
For compound 4 the middle estimate is 3.0-fold (0.47 log units) below the measured one; measured number above the stated range.
By their numbers in this assay, from the lowest: compounds 3, 2, 4 and 1 (each within the scatter of the next, the first and the last beyond it).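

The earlier compounds shown here varied only the group on the amine nitrogen in the ring, whereas this pair shows that the group on the amide-type nitrogen also matters. In this assay, naphthalen-1-yl in place of phenyl gives a 2.3-fold higher number from compound 3 to compound 4 (0.35 log units; beyond the scatter), so the added ring weakens compound 4 modestly rather than helping. Nothing available explains this shift.

Still open, going by these compounds, is whether a simple methyl, a cyclohexyl or a phenyl carrying a methoxy group would keep or improve on phenyl. The compounds shown also leave open how naphthalen-2-yl would compare with naphthalen-1-yl.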